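Sulfanyl and methylsulfanyl analogues: all at the assay limit

The compounds below may be only part of what the source reports. "The series", "measured", "known", "first", "only" and "open" are said of these compounds alone.

Compound 1 `Cc1nnc(S)n2c(C)nc(C)c12` was run in a functional assay for inhibition, with Homo sapiens as the target; on this read-out lower numbers stand for stronger inhibition and higher numbers for weaker inhibition. Compound 1 gives > 48000 nM, which is a limit of the assay and not a number. Compound 2 `CSc1nnc(C)c2c(C)nc(C)n12` in this assay gives > 48000 nM, again a limit rather than a number. Compound 3 `CCCc1nnc(SC)n2c(CCC)nc(C)c12` in this assay gives > 48000 nM, also a limit. The change from compound 2 to compound 1 hydrogen in place of methyl on a sulfur reads as a step that the two limits leave unreadable from compound 2 to compound 1, since the limit of > 48000 nM in this assay, at which 3 of the 3 values shown sit, holds both ends of that pair. The difference between the cores of compound 2 and compound 3 is not broken down here. Compound 4 `CCCc1nnc(S)n2c(CCC)nc(C)c12` is not yet measured in this assay; it differs from compound 3 by hydrogen in place of methyl on a sulfur, the same change as the measured pair, at a place described in the same words. Because the limit of > 48000 nM in this assay, at which 3 of the 3 values shown sit, sits on every value shown, compound 4 is expected to remain at the limit too, so the expected step that the limit leaves unreadable from compound 3 to compound 4 is set close to no change. Compound 4 is estimated at 100000 nM in this assay, most likely between 48000 nM and 300000 nM, with a limit rather than a number the probable outcome.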

Compound 4, half-maximal inhibitory concentration: > 48000 nM
Compound 4: a limit, no number; the forecaster's own chance of this, stated with the estimate: 85%; the middle value is on the limit's open side.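

In this assay compound 4 gives > 48000 nM which is a limit and not a number. No step can be read between compound 3 and compound 4, and the same holds for compound 2 and compound 1, since all of these values sit at one limit: the limit of > 48000 nM in this assay, at which 4 of the 4 values shown sit.

The compounds shown leave open what the methylsulfanyl to sulfanyl change does to inhibition wherever a measured number exists.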